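From 2-chlorobenzyl to 3-chlorobenzyl: an expected shift

The source may hold more compounds than are shown below. What is called first, only, known or untested is meant among the compounds shown, and "the series" means these compounds.

Of the compounds shown here, three sharing one core have been measured in a functional assay on the whole organism with Rattus norvegicus as the target; on this read-out lower numbers stand for an effect already at smaller amounts and higher numbers for an effect only at larger amounts of compound: compound 1 `CCN(CCNC(=O)c1cc(Cl)c(N)cc1OC)Cc1ccoc1` gives 3 mg/kg, compound 2 `CCN(CCNC(=O)c1cc(Cl)c(N)cc1OC)Cc1cccc(OC)c1` gives 1 mg/kg, and compound 3 `CCN(CCNC(=O)c1cc(Cl)c(N)cc1OC)Cc1ccccc1Cl` gives 10 mg/kg. Compound 3 thus holds the highest of the three numbers, and both gaps to it lie beyond the scatter: a 3.3-fold higher number from compound 1 to compound 3 (0.52 log units; beyond the scatter) and a 10-fold higher number from compound 2 to compound 3 (1.00 log units; beyond the scatter).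

Compound 4 `CCN(CCNC(=O)c1cc(Cl)c(N)cc1OC)Cc1cccc(Cl)c1` keeps the core and puts 3-chlorophenyl in place of 2-chlorophenyl on a saturated chain carbon bound to an amine nitrogen. Among the measured compounds shown here, no measured step makes this exact change. The closest guide is the replacement of 3-methoxyphenyl by 2-chlorophenyl, a 10-fold higher number from compound 2 to compound 3 (1.00 log units; beyond the scatter), the largest step seen so far. The other exchange at this place, a 3.0-fold lower number from compound 1 to compound 2 (0.48 log units; beyond the scatter), shows that the number also responds to groups other than 2-chlorophenyl. Compound 4 shares its chlorine with compound 3 and the 3- in its group name with compound 2, and the data cannot separate those two features. A partial return towards compound 2 is therefore expected, and the expected change is a 5.0-fold lower number from compound 3 to compound 4 (0.70 log units; beyond the scatter). For compound 4 the estimated value in this assay is 2 mg/kg, with an expected range of 0.7 mg/kg to 6 mg/kg.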

Compound 4, dose for half-maximal effect: 0.58 mg/kg
For compound 4 the middle estimate is 3.4-fold (0.54 log units) above the measured one; the measured number lies below the stated range.
By their numbers in this assay, from the lowest: compounds 4 and 2 (each within the scatter of the next); then compound 1; then compound 3.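

With the same atoms joined differently, 3-chlorophenyl in place of 2-chlorophenyl on a saturated chain carbon bound to an amine nitrogen gives in this assay a 17-fold lower number from compound 3 to compound 4 (1.24 log units; beyond the scatter) and is the largest step yet seen at this place, so the presence of chlorine alone does not go with the high number of compound 3. The earlier compounds shown here could not separate the chlorine from the group's arrangement, but chloro in place of methoxy on an aromatic carbon now gives a 1.7-fold lower number from compound 2 to compound 4 (0.24 log units; within the scatter) and leaves no readable difference between the 3-chlorophenyl and 3-methoxyphenyl compounds, while the exchange with furan-3-yl gives a 5.2-fold lower number from compound 1 to compound 4 (0.71 log units; beyond the scatter) and places 3-chlorophenyl clearly on the lower side. Nothing available here explains why exchanging these two chlorophenyl groups changes the number so strongly.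

From the compounds shown here alone, how 4-chlorophenyl would read at this place remains open, as does whether 2-methoxyphenyl would stand as far from 3-methoxyphenyl as 2-chlorophenyl stands from 3-chlorophenyl. Going by these compounds, it is also open whether 3-aminophenyl or 3-cyanophenyl, with an amine or a nitrile in place of the chloro, would keep the number as low as compound 4 does.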